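The source may report more compounds than this note shows. Statements on the series, on what has been measured and on what is new or still open speak of the compounds shown alone.

Compound 1 `CCCCn1nc(-c2ccccc2)c(-c2ccccc2)cc1=O`: 176000 nM
Compound 2 `CCCCCCn1nc(-c2ccccc2)c(-c2ccccc2)cc1=O`: 57000 nM
Compound 3 `CCCCCCn1nc(-c2ccccc2)c(-c2ccccc2)c(C)c1=O`: 56000 nM

In an assay on microsomes from liver for inhibition of sterol O-acyltransferase 1 (Rattus norvegicus) (on this read-out higher numbers stand for weaker inhibition and lower numbers for stronger inhibition), compound 1 stands highest of the three numbers; compound 2 lies a step below it, a 3.1-fold lower number from compound 1 to compound 2 (0.49 log units; beyond the scatter), and compound 3 sits at the same level as compound 2 within the scatter. Compound 4 `O=C(O)CCCCCCCn1nc(-c2ccccc2)c(-c2ccccc2)cc1=O` differs from compound 1 by 3-carboxypropyl in place of hydrogen on a saturated chain carbon, four bonds along the chain from an aromatic nitrogen. Going by the values given here, the one step that bears on this change is the chain extension at the same place, a 3.1-fold lower number from compound 1 to compound 2 (0.49 log units; beyond the scatter), which was modest and beyond the scatter. Among the compounds with values here, no measured step covers the carboxy group that ends the new chain; the step of a 1.0-fold lower number from compound 2 to compound 3 (0.01 log units; within the scatter) concerns a different position and tells nothing here. On that basis a step of similar size and direction is expected, a 3.2-fold lower number from compound 1 to compound 4 (0.51 log units; beyond the scatter). Compound 4 is therefore estimated at 55000 nM in this assay, with a range from 15000 nM to 200000 nM.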

Compound 4, half-maximal inhibitory concentration: > 300000 nM
Compound 4 was reported as a limit (the forecaster's own chance of this, stated with the estimate: 20%); at least 5.4-fold (0.73 log units) between middle value and limit.
By their numbers in this assay, from the lowest: compounds 3 and 2 (each within the scatter of the next); then compound 1. At a limit, above all of these: compound 4.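

In this assay compound 4 is reported only as a limit: the limit of > 300000 nM in this assay, at which 1 of the 4 values shown sits. The earlier gain from lengthening the chain at this position does not carry over once the chain ends in a carboxy group, as carboxymethyl on the hexyl chain reverses the direction, an at least 5.2-fold higher number from compound 2 to compound 4 (0.72 log units; beyond the scatter). Against the shorter chain the step is an at least 1.7-fold higher number from compound 1 to compound 4 (0.23 log units; that floor lies within the scatter), so it adds little on its own.

From the compounds shown here alone, whether the carboxylic acid or the chain length drives this stays open. A longer alkyl chain without the acid, or a methyl ester or primary amide at the chain end, would separate the two.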